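The source may report more compounds than this note shows. Statements on the series, on what has been measured and on what is new or still open speak of the compounds shown alone.

In a functional assay on KB cells (Homo sapiens) for antiproliferative activity, read by MTT assay, with a stated time of 72 h (on this read-out higher numbers stand for weaker inhibition and lower numbers for stronger inhibition), compound 1 `CN(c1ccc2[nH]c(-c3n[nH]c4ccccc34)cc2n1)S(=O)(=O)c1ccccc1` gives 2400 nM, compound 2 `Cc1ccc(S(=O)(=O)N(C)c2ccc3[nH]c(-c4n[nH]c5ccccc45)cc3n2)cc1` gives 9500 nM, and compound 3 `CN(c1ccc2[nH]c(-c3n[nH]c4ccccc34)cc2n1)S(=O)(=O)c1ccc(Br)cc1` gives 7150 nM, the second highest of the three numbers. Compound 4 `COc1ccc(S(=O)(=O)N(C)c2ccc3[nH]c(-c4n[nH]c5ccccc45)cc3n2)cc1OC` differs from compound 3 by 3,4-dimethoxyphenyl in place of 4-bromophenyl on a sulfonyl sulfur. For the measured compounds named here, two measured steps bear on this change: the one from compound 1 to compound 3 a 3.0-fold higher number from compound 1 to compound 3 (0.47 log units; beyond the scatter) and the one from compound 1 to compound 2 a 4.0-fold higher number from compound 1 to compound 2 (0.60 log units; beyond the scatter), both modest rises, while the step from compound 2 to compound 3 a 1.3-fold lower number from compound 2 to compound 3 (0.12 log units; within the scatter) stayed within the scatter. Since each substituted phenyl so far gave a higher number than the unsubstituted one, compound 4 is expected to stay near compound 3 or rise slightly, a step of a 1.2-fold higher number from compound 3 to compound 4 (0.08 log units; within the scatter) in this assay. Compound 4 is therefore estimated at 8500 nM, with a range from 3500 nM to 20000 nM.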

Compound 4, half-maximal inhibitory concentration: 10100 nM
Compound 4: the middle estimate sits 1.2-fold (0.07 log units) below what was measured; the range from low to high includes it.
By their numbers in this assay, from the lowest: compound 1; then compounds 3, 2 and 4 (each within the scatter of the next).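

Swapping the group on the sulfonyl sulfur moves the number little in this assay: 3,4-dimethoxyphenyl in place of 4-bromophenyl gives (a 1.4-fold higher number from compound 3 to compound 4 (0.15 log units; within the scatter)), and in place of 4-methylphenyl gives (a 1.1-fold higher number from compound 2 to compound 4 (0.03 log units; within the scatter)). The three substituted phenyls therefore cannot be told apart, while against the plain phenyl the dimethoxy compound shows (a 4.2-fold higher number from compound 1 to compound 4 (0.62 log units; beyond the scatter)), and no listed substituted phenyl goes against that rise. Nothing shown explains this. On these data alone, whether a methyl or a longer alkyl chain on the sulfonyl sulfur in place of the phenyl, or an amine on the phenyl, would match or pass compound 1 remains open.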